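A Cyclopropyl Extension on the Aryl Ether Chain

The source may hold more compounds than are shown below. What is called first, only, known or untested is meant among the compounds shown, and "the series" means these compounds.

Compound 3 `CCOc1ccc(Cl)cc1NC(=O)CN1CCN(S(=O)(=O)N2CCC(C)CC2)CC1` has been measured in an assay on HEK293 cells for inhibition of potassium channel subfamily T member 1 (Homo sapiens), read by thallium flux (a higher number here means a weaker inhibitor, a lower number a stronger inhibitor), where compound 3 gives 7100 nM. Its nearest neighbour is compound 1 `CC1CCN(S(=O)(=O)N2CCN(CC(=O)Nc3cc(Cl)ccc3OC(C)C)CC2)CC1`, which in this assay gives 5100 nM; the step of a 1.4-fold higher number from compound 1 to compound 3 (0.14 log units; within the scatter) lies within the scatter, so the two cannot be told apart. Compound 2 `Cc1ccc(Cl)cc1NC(=O)CN1CCN(S(=O)(=O)N2CCC(C)CC2)CC1` gives only a limit in this assay, > 10000 nM. Both an at least 1.4-fold lower number from compound 2 to compound 3 (0.14 log units; that floor lies within the scatter) and an at least 1.9-fold higher number from compound 1 to compound 2 (0.29 log units; that floor lies within the scatter) run through the limit of > 10000 nM in this assay, at which 1 of the 3 values shown sits, and so set only a floor.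

Compound 4 `CC1CCN(S(=O)(=O)N2CCN(CC(=O)Nc3cc(Cl)ccc3OCC3CC3)CC2)CC1` differs from compound 3 in one place: cyclopropyl in place of methyl on a saturated chain carbon bound to an oxygen on an aromatic ring. The step that bears most directly on it is a 1.4-fold higher number from compound 1 to compound 3 (0.14 log units; within the scatter), where the chain on that same carbon shrank from methyl to hydrogen and the number moved only within the scatter. Growing the chain again, now to cyclopropyl, is therefore expected to move the number little, and the expected step is a 1.3-fold lower number from compound 3 to compound 4 (0.11 log units; within the scatter). For compound 4 the estimate is 5500 nM, with a range from 2500 nM to 12000 nM.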

Compound 4, half-maximal inhibitory concentration: 7500 nM
Compound 4: middle estimate off by 1.4-fold (0.13 log units), on the low side; measured number inside the range.
By their numbers in this assay, from the lowest: compounds 1, 3 and 4 (each within the scatter of the next). At a limit, above all of these: compound 2.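

In this assay the step of a 1.1-fold higher number from compound 3 to compound 4 (0.02 log units; within the scatter) and the step of a 1.5-fold higher number from compound 1 to compound 4 (0.17 log units; within the scatter) show that this position takes a cyclopropyl group, with its three-membered ring, with no change that can be told from the scatter. Until now only the exchange of methyl and hydrogen on this carbon had been seen, so the flat result now extends to a larger group of 3 heavy atoms. The remaining step of an at least 1.3-fold lower number from compound 2 to compound 4 (0.12 log units; that floor lies within the scatter) sets only a floor, and it runs through a limit: the limit of > 10000 nM in this assay, at which 1 of the 4 values shown sits.

No change at this position among the ethers shown moves the number beyond the scatter. As far as these compounds go, whether a longer chain such as n-butyl, or an amine at the end of the chain, would do so remains open.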